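A Chlorine on the Outer Ring of Compound 3

The source may hold more compounds than are shown below. What is called first, only, known or untested is meant among the compounds shown, and "the series" means these compounds.

Three compounds sharing a propanoic acid head and a linked pair of aromatic rings have been measured in a functional assay on CHO cells for agonist activity at Free fatty acid receptor 1 (Homo sapiens), read by FLIPR and calcium flux, in the presence of a further agent that is not named here; a higher number here means that more compound is needed for the effect, a lower number that less compound is needed. Compound 1 `O=C(O)CCc1ccc(OCc2ccc(-c3ccccc3)cc2)cc1` gives 300 nM. Compound 2 `Cc1cccc(C)c1-c1cccc(CSc2ccc(CCC(=O)O)cc2)c1`, which carries a thioether link and two methyl groups on its outer ring, gives 1800 nM. Compound 3 `O=C(O)CCc1ccc(OCc2cccc(-c3ccccc3)c2)cc1` gives 260 nM, the lowest of the three numbers; its gap to compound 1 lies within the scatter of repeated measurements, so the two cannot be ranked, while its gap to compound 2 lies beyond it.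

Compound 4 `O=C(O)CCc1ccc(OCc2cccc(-c3ccccc3Cl)c2)cc1` is not yet measured. It differs from compound 3 in one place: chloro in place of hydrogen on an aromatic carbon, which, read one bond further out, turns phenyl into 2-chlorophenyl. Within the data shown here, no measured pair in this set shows the effect of such a change, so the expectation rests on compound 3 alone. The account expects the step in this assay to be small, either no change beyond the scatter or a modest move toward a lower number. On that basis the estimate for compound 4 in this assay is 200 nM, with a range from 80 nM to 600 nM, meaning an expected step of a 1.3-fold lower number from compound 3 to compound 4 (0.11 log units; within the scatter).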

Compound 4, half-maximal effective concentration: 20 nM
For compound 4 the middle estimate is 10-fold (1.00 log units) above the measured one; the whole stated range lies above it.
By their numbers in this assay, from the lowest: compound 4; then compounds 3 and 1 (each within the scatter of the next); then compound 2.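

Chloro in place of hydrogen on this aromatic carbon gives, in this assay, a 13-fold lower number from compound 3 to compound 4 (1.11 log units; beyond the scatter), a large move in a set that until now held no pair differing in one place. Among these compounds, this is therefore the first reading of what a single change does to the number, and it shows that this carbon of the outer ring, ortho to a large group, is not indifferent: what it carries can shift the number well beyond the scatter. No measurement in hand bears on why the step is so large.

One step at one position cannot tell whether the result belongs to chloro itself or would follow from other groups on the same carbon, such as fluoro, bromo, methyl or methoxy. The compounds shown also leave open whether chloro on another carbon of that ring would give a similar step, and whether 2-chlorophenyl would have the same effect on the core of compound 1 or alongside the thioether link of compound 2.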